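Replacing the oxadiazolyl group: working notes on compound 4

The source may hold more compounds than are shown below. What is called first, only, known or untested is meant among the compounds shown, and "the series" means these compounds.

Measured so far in a physicochemical assay for solubility, using the shake flask method, in simulated intestinal fluid, measured as kinetic solubility, with a stated time of 2 h, at 25 degrees C, at pH 6.5; on this read-out higher numbers stand for higher solubility and lower numbers for lower solubility:
- compound 1 `CCCOC(=O)c1nc(C)c2c(c1N)C(=O)N(Cc1ccccc1)C2=O`: < 5000 nM (a limit)
- compound 2 `Cc1nc(C(=O)OC2CC2)c(N)c2c1C(=O)N(Cc1ccccc1)C2=O`: 202000 nM
- compound 3 `Cc1nnc(-c2nc(C)c3c(c2N)C(=O)N(Cc2ccccc2)C3=O)o1`: < 5000 nM (a limit)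

Compound 3 gives < 5000 nM, which is a limit and not a number. That is the limit of < 5000 nM in this assay, at which 2 of the 3 values shown sit.

Compound 4 `Cc1nc(C(=O)NC#N)c(N)c2c1C(=O)N(Cc1ccccc1)C2=O` carries cyanocarbamoyl in place of 5-methyl-1,3,4-oxadiazol-2-yl on an aromatic carbon, next to the ring nitrogen and ortho to an amino group: cyanocarbamoyl in place of 5-methyl-1,3,4-oxadiazol-2-yl on an aromatic carbon.

The closest evidence is an at least 40-fold lower number from compound 2 to compound 3 (1.60 log units; beyond the scatter), where the same oxadiazolyl group replaces cyclopropyloxycarbonyl. Compound 4 returns a carbonyl group to that aromatic carbon, as in compound 2, so a move upward in this assay is expected. Compound 1 goes against any simple carbonyl pattern, as an at least 40-fold higher number from compound 1 to compound 2 (1.60 log units; beyond the scatter) shows that the carbonyl group alone does not set the outcome. The other step, a step that the two limits leave unreadable from compound 1 to compound 3, adds nothing on size. Within the data shown here, no measured compound carries cyanocarbamoyl, so a large step is expected only with wide uncertainty, and compound 4 may yet stay at the limit.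

The expected change is an at least 8.0-fold higher number from compound 3 to compound 4 (0.90 log units; beyond the scatter).

The estimate for compound 4 is 40000 nM, with an expected range of 5000 nM to 250000 nM.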

Compound 4, solubility: 185000 nM
For compound 4 the middle estimate is 4.6-fold (0.67 log units) below the measured one, and the stated range covers the measured number.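

In this assay, among these compounds, cyanocarbamoyl in place of 5-methyl-1,3,4-oxadiazol-2-yl on this aromatic carbon gives an at least 37-fold higher number from compound 3 to compound 4 (1.56 log units; beyond the scatter), the first step at this position that starts from the oxadiazolyl compound and can be read. On the carbonyl carbon, cyanoamino and cyclopropyloxy cannot be told apart, with a 1.1-fold lower number from compound 2 to compound 4 (0.04 log units; within the scatter), so compound 2 no longer stands alone among the carbonyl compounds shown. Cyanoamino in place of propoxy gives an at least 37-fold higher number from compound 1 to compound 4 (1.56 log units; beyond the scatter), which leaves compound 1 as the one carbonyl compound that goes against a pattern of carbonyl compounds standing clear of the limit: the limit of < 5000 nM in this assay, at which 2 of the 4 values shown sit.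

As far as these compounds go, compound 1 and compound 3 each stand at a limit and not at a number, so the full size of the steps from them remains open. Also open, from the compounds shown here alone, is whether the match between compound 2 and compound 4 extends to other groups on that carbonyl carbon, such as a hydroxyl group as in a carboxylic acid, a plain amino group as in a primary amide, or a longer alkoxy chain.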